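Swapping a Methoxyphenyl for a Difluorophenyl on the Ketone

The source may report more compounds than this note shows. Statements on the series, on what has been measured and on what is new or still open speak of the compounds shown alone.

Of the compounds shown here, two sharing one core have been tested in a functional assay on IGROV-1 cells (Homo sapiens) for cytotoxicity, read by sulforhodamine B assay, with a stated time of 48 h, tested at 0.1 uM; on this read-out lower numbers stand for a stronger effect and higher numbers for a weaker effect at the one concentration tested. Compound 1 `COc1ccc(-c2cc(/C=C/C(=O)c3cc(OC)c(OC)c(OC)c3)[nH]n2)cc1OC` gives 97% in this assay. Compound 2 `COc1ccc(C(=O)/C=C/c2cc(-c3cc(OC)c(OC)c(OC)c3)n[nH]2)cc1` gives 102% in this assay, a number that sits alongside that of compound 1 within the usual scatter, so the two cannot be told apart and both leave most cells unharmed at the single concentration tested. Compound 3 `COc1cc(-c2cc(/C=C/C(=O)c3ccc(F)c(F)c3)[nH]n2)cc(OC)c1OC` has not yet been measured. It differs from compound 2 in one place: 3,4-difluorophenyl in place of 4-methoxyphenyl on a carbonyl carbon. Going by the values given here, no measured pair shows what such an exchange does, so the only guide is that compound 2 gives 102% and compound 1 gives 97%. Compound 3 is therefore expected to stay close, with an expected step of a number 5 percentage points lower from compound 2 to compound 3 (within the scatter) that does not go beyond the scatter. The estimate for compound 3 in this assay is 97%, within a range from 80% to 106%.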

Compound 3, a percentage reported as activity, at one concentration (the size of the read-out at that concentration, not a potency): 97%
Beside the measured number, compound 3's estimate shows no gap at the digits printed; low and high end bracket the measured number.
By their numbers in this assay, from the lowest: compounds 1, 3 and 2 (each within the scatter of the next).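

Exchanging 4-methoxyphenyl for 3,4-difluorophenyl on a carbonyl carbon gives, in this assay, a number 5 percentage points lower from compound 2 to compound 3 (within the scatter), so compound 2 and compound 3 cannot be told apart. This is the first pair shown that differs in one place, and it shows that this position tolerates the loss of the hydrogen-bond acceptor counted on the 4-methoxyphenyl group and the arrival of two fluorines, with no effect beyond the scatter at the one concentration tested. Nothing available explains this outcome.

Going by these compounds, since this single concentration separates neither compound, it remains open whether the exchange would matter at a higher concentration. On these data alone, it is also open whether a different kind of group on that carbonyl carbon, such as an amine or a phenyl ring carrying a carboxylic acid, would alter the result in this assay.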